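A few compounds are considered here, and "the series" means these few. Any claim that something is new, unique, unknown or untested is made for them only; others in the source may bear on it.

Of the two numbers measured in a functional assay on PC-3 cells (Homo sapiens) for inhibition (a higher number here means a weaker inhibitor, a lower number a stronger inhibitor), compound 2 `Cc1c(C(=O)N/N=C\c2cccc(O)c2O)oc2cccc(O)c12` gives 12200 nM and compound 1 `Cc1c(C(=O)N/N=C\c2c(O)cccc2F)oc2cccc(O)c12` gives 8050 nM; a 1.5-fold higher number from compound 1 to compound 2 (0.18 log units; within the scatter). Compound 3 `Cc1ccc(O)c(/C=N\NC(=O)c2oc3cccc(O)c3c2C)c1` carries 2-hydroxy-5-methylphenyl in place of 2,3-dihydroxyphenyl on a carbon with a double bond to nitrogen. Among the compounds with values here, the one measured step at this carbon, a 1.5-fold higher number from compound 1 to compound 2 (0.18 log units; within the scatter), stayed within the scatter, and no measured step swaps a hydroxyl for a methyl at this place, so nothing points to a shift beyond the scatter in this assay. The step expected here is a 1.2-fold lower number from compound 2 to compound 3 (0.09 log units; within the scatter). Compound 3 is estimated at 10000 nM, with a range from 3000 nM to 35000 nM.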

Compound 3, half-maximal inhibitory concentration: 7350 nM
Estimate against measurement, compound 3: 1.4-fold (0.13 log units) above; low and high end bracket the measured number.
By their numbers in this assay, from the lowest: compounds 3, 1 and 2 (each within the scatter of the next).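

With 2-hydroxy-5-methylphenyl on the carbon with a double bond to nitrogen, this assay shows a 1.7-fold lower number from compound 2 to compound 3 (0.22 log units; within the scatter) and a 1.1-fold lower number from compound 1 to compound 3 (0.04 log units; within the scatter) for the change from 2-fluoro-6-hydroxyphenyl. A methyl-bearing group therefore joins the hydroxyl- and fluorine-bearing groups here with no step beyond the scatter, even with the lower donor and acceptor counts of 2-hydroxy-5-methylphenyl. No supporting measurement accounts for these small steps.

Still open, from the compounds shown here alone, is whether an amine or a carboxylic acid on this ring would shift the number beyond the scatter. An unsubstituted phenyl is equally untested among the compounds shown here.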